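This account rests on a few compounds, and the source may have more. Where it says the series, first, only, none or still open, it means among the compounds named here.

Compound 1, `OCC#CCSc1cnc2ccccc2c1[Se]CC#CCO`, is the stronger-looking of the two measured entries in a functional assay on B16 cells (Mus musculus) for cytotoxicity, read by sulforhodamine B assay, with a stated time of 72 h; a higher number here means a weaker inhibitor, a lower number a stronger inhibitor: compound 1 gives 4.3 ug/mL, the lowest of the two numbers, while compound 2, `C#CC[Se]c1c(SCC#CCO)cnc2ccccc12`, gives 6.8 ug/mL. Among the measured compounds shown here, the only step available, a 1.6-fold higher number from compound 1 to compound 2 (0.20 log units; within the scatter), shows that trimming the alkyne on the selenium side left the result within the scatter. Compound 3, `CSc1cnc2ccccc2c1[Se]CC#CCO`, has not yet been measured in this assay; it differs from compound 1 by hydrogen in place of 3-hydroxyprop-1-yn-1-yl on a saturated chain carbon bound to a sulfur, a larger cut on the sulfur side, taking the whole 4-hydroxybut-2-yn-1-yl down to methyl. For the measured compounds named here, the one measured step concerns a different arm and was itself within the scatter, so it gives no firm pointer; a modest rise in the number, if anything, is expected. Compound 3 is therefore estimated at 6.5 ug/mL, between 3 ug/mL and 15 ug/mL, a step of a 1.5-fold higher number from compound 1 to compound 3 (0.18 log units; within the scatter).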

Compound 3, concentration for 50% inhibition: 4.2 ug/mL
Estimate against measurement, compound 3: 1.5-fold (0.19 log units) above; the measured number falls inside the stated range.
By their numbers in this assay, from the lowest: compounds 3, 1 and 2 (each within the scatter of the next).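

Compound 3 shows that the sulfur arm of compound 1 can be cut from 4-hydroxybut-2-yn-1-yl to methyl with a step of a 1.0-fold lower number from compound 1 to compound 3 (0.01 log units; within the scatter) in this assay. Among the compounds shown here, the earlier step touched only the selenium side, so this is the first reading on the sulfur side, and it shows that losing 3-hydroxyprop-1-yn-1-yl, with its 4 heavy atoms, triple bond and hydroxyl, on a saturated chain carbon bound to a sulfur leaves the two compounds indistinguishable here. No evidence is at hand that bears on this result.

From the compounds shown here alone, whether an amine, a carboxylic acid or a longer chain in this place would also stay within the scatter remains open. So does whether a methyl on the selenium side, alone or with the methyl on sulfur, would read the same way.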